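A few compounds are considered here, and "the series" means these few. Any claim that something is new, unique, unknown or untested is made for them only; others in the source may bear on it.

The measured compounds and their results:
- Compound 1, `COc1ccc(-c2ccc(-c3ccc(C(=N)N)cc3)s2)cc1`, gives 1270 nM
- Compound 2, `COc1cc(OC)cc(-c2ccc(-c3ccc(C(=N)N)c(F)c3)s2)c1`, gives 1590 nM
- Compound 3, `COc1ccc(-c2ccc(-c3ccc(C(=N)N)c(F)c3)s2)cc1`, gives "not determined" (no result reported)

All three share the same core, and the numbers come from a functional assay on SF-295 cells (Homo sapiens) for inhibition, read by sulforhodamine B assay, with a stated time of 48 h; a higher number here means a weaker inhibitor of growth, a lower number a stronger inhibitor of growth. Compound 1 has the lowest of the two reported numbers, but its nearest neighbour, compound 2, sits within the usual scatter of it, so the two cannot be told apart on these data. Compound 3 adds nothing to the comparison, since no number was reported for it.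

The next compound, compound 4, `N=C(N)c1ccc(-c2ccc(-c3ccc(Cl)cc3)s2)cc1`, has not been measured in this assay. It differs from compound 1 in one place:

chloro in place of methoxy on an aromatic carbon

Within the data shown here, no pair of measured compounds shows what a change of this kind does here, so there is no measured step to lean on. A methoxy and a chloro group on the same aromatic carbon are both small substituents, and with nothing in the data pointing either way, the expected step from compound 1 to compound 4 is a 1.0-fold higher number from compound 1 to compound 4 (0.01 log units; within the scatter), that is, no change beyond the scatter. On that basis compound 4 is estimated at 1300 nM, with a range from 500 nM to 3500 nM.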

Compound 4, concentration for 50% growth inhibition: 171 nM
Beside the measured number, compound 4's estimate is 7.6-fold (0.88 log units) above it, outside the stated range (below it).
By their numbers in this assay, from the lowest: compound 4; then compounds 1 and 2 (each within the scatter of the next).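

In this assay, among these compounds, putting chloro in place of methoxy on this aromatic carbon, para to a large group, gives a 7.4-fold lower number from compound 1 to compound 4 (0.87 log units; beyond the scatter) and is the first step here that lies beyond the scatter. The earlier numbers could not show this, and the pair now shows that this position is not indifferent to its substituent: with the rest of compound 1 untouched, one group exchanged for another moves the result clearly toward stronger inhibition of growth. Nothing available here accounts for the size or direction of this step.

From the compounds shown here alone, a single pair cannot separate what chloro brings from what the departure of methoxy removes, so it stays open how a bromo, a methyl, a trifluoromethyl or an amine on the same carbon would compare with these two groups. Going by these compounds, it is also open whether the same exchange would give a step of similar size on a core that carries a fluoro group as well, as compound 3 does.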